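This account rests on a few compounds, and the source may have more. Where it says the series, first, only, none or still open, it means among the compounds named here.

In a functional assay (a higher number here means a weaker inhibitor, a lower number a stronger inhibitor), compound 1 `CC(C)=CCOc1cc(O)c2c(c1)OC(c1ccccc1)CC2=O` gives 7320 nM and compound 2 `CC(C)=CCOc1cc(O)c2c(c1)OC(c1ccccc1F)CC2=O` gives 5300 nM, so these two numbers stand within the scatter of each other. Compound 3 `CC(C)=CCOc1cc(O)c2c(c1)OC(c1cccc(F)c1)CC2=O` has 3-fluorophenyl in place of 2-fluorophenyl on a saturated ring carbon. Going by the values given here, the only measured step that bears on this is a 1.4-fold lower number from compound 1 to compound 2 (0.14 log units; within the scatter), which introduced the fluoro group on an aromatic carbon. Going by that small step, no change beyond the scatter is expected in this assay, and no direction can be favoured. The expected step is a 1.0-fold higher number from compound 2 to compound 3 (0.02 log units; within the scatter). The estimate for compound 3 is 5500 nM, with an expected range from 2600 nM to 11500 nM.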

Compound 3, half-maximal inhibitory concentration: 7240 nM
Beside the measured number, compound 3's estimate is 1.3-fold (0.12 log units) below it; low and high end bracket the measured number.
By their numbers in this assay, from the lowest: compounds 2, 3 and 1 (each within the scatter of the next).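

In this assay the swap of 2-fluorophenyl for 3-fluorophenyl on this saturated ring carbon gives a 1.4-fold higher number from compound 2 to compound 3 (0.14 log units; within the scatter) and so adds a second fluorinated comparison. The fluoro in place of hydrogen on an aromatic carbon gives a 1.0-fold lower number from compound 1 to compound 3 (0.00 log units; within the scatter) as its second reading. Neither the presence of this fluoro group nor the difference between these two fluorophenyl groups separates the compounds in this assay. No supporting measurement speaks to why. Still open, as far as these compounds go, is whether a methoxy group, an amine or a carboxylic acid on that phenyl ring would shift the number beyond the scatter.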